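Chloro Substitution on the Anilide Ring of Dithioester Anilides

The source may report more compounds than this note shows. Statements on the series, on what has been measured and on what is new or still open speak of the compounds shown alone.

Of the compounds shown here, three have been measured in a functional assay on KB cells (Homo sapiens) for inhibition, read by MTT assay, with a stated time of 24 h, tested at 10 ug/mL; a higher number here means more inhibition of growth at the concentration tested, a lower number less inhibition of growth. Compound 1, `CC(=O)SCCC(CCCCC(=O)Nc1ccccc1)SC(C)=O`, gives 2.5%. Compound 2, `CC(=O)SCCC(CCCCC(=O)Nc1ccc(Cl)cc1)SC(C)=O`, gives 18.1% in this assay. Compound 3, `O=C(CCCCC(CCSC(=O)c1ccccc1)SC(=O)c1ccccc1)Nc1ccccc1`, gives 2.67% in this assay. The change from compound 1 to compound 2 is chloro in place of hydrogen on an aromatic carbon, and it made a step of a number 15.6 percentage points higher from compound 1 to compound 2 (beyond the scatter). Compound 3 differs from compound 1 in its core, and that difference between the two cores is not broken down here; the values of compound 3 and compound 1 lie within the scatter of each other.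

Compound 4, `O=C(CCCCC(CCSC(=O)c1ccccc1)SC(=O)c1ccccc1)Nc1ccccc1Cl`, is not yet measured. It differs from compound 3 by chloro in place of hydrogen on an aromatic carbon. This is the same kind of change as that from compound 1 to compound 2, but the place differs: there the chloro stands para to a large group, here ortho to a large group. Given the earlier step in this assay, a step of a number 7.3 percentage points higher from compound 3 to compound 4 (within the scatter) is expected from compound 3 to compound 4. That expected step is kept smaller than the earlier one: the place of the chloro is not the same, and the earlier step rests on a single pair. Compound 4 is therefore estimated at 10% in this assay, between 0% and 25%.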

Compound 4, percent growth inhibition at one concentration: 2.53%
Compound 4: the middle estimate sits 7.5 percentage points above what was measured; the range from low to high includes it.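

Setting chloro in place of hydrogen on the aromatic ring gave a number 0.1 percentage points lower from compound 3 to compound 4 (within the scatter) in this assay, so the rise seen with the same change on the core of compound 1 did not appear in this pair. The two steps do not match: the same change on two cores in this assay, a number 15.6 percentage points higher (beyond the scatter) from compound 1 to compound 2 and a number 0.1 percentage points lower (within the scatter) from compound 3 to compound 4, 15.7 percentage points apart, beyond the scatter of two such steps This does not show that the core alone decides the outcome: the two pairs also differ in the place of the chloro, which in compound 4 stands ortho to a large group and in compound 2 does not, and each step rests on a single pair.

The compounds shown leave open whether chloro in its compound 2 place would raise the number on the core of compound 3, and whether chloro in its compound 4 place would do so on the core of compound 1. They also leave open how a fluoro, a methyl or a methoxy on the same ring, or a longer chain in place of the present one, would read.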